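The source may report more compounds than this note shows. Statements on the series, on what has been measured and on what is new or still open speak of the compounds shown alone.

Working notes, carbamate series, read in an assay on BTI-TN-5B1-4 cells for inhibition of Amine oxidase [flavin-containing] A (Homo sapiens), read by fluorescence and Amplex Red, using microsomes, with a stated time of 15 min; on this read-out lower numbers stand for stronger inhibition and higher numbers for weaker inhibition.

Compound 1 `C#CCN1CCC(OC(=O)Nc2ccccc2)CC1` reaches only the limit of this assay, > 100000 nM. Compound 2 `O=C(Nc1ccccc1)OC1CCN(Cc2ccccc2)CC1` likewise gives only a limit in this assay, > 100000 nM. Compound 3 `C#CCN1CCCC(COC(=O)Nc2ccc(C(C)C)cc2)C1` also stands at the limit of this assay, > 100000 nM.

Among the measured compounds shown here, the single change from compound 1 to compound 2 is phenyl in place of ethynyl on a saturated chain carbon bound to an amine nitrogen in a ring. The step it made, a step that the two limits leave unreadable from compound 1 to compound 2, cannot be read in either direction, both ends being limits. How the core of compound 1 and the core of compound 3 differ is not broken down here.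

Compound 4 `CC(C)c1ccc(NC(=O)OCC2CCCN(Cc3ccccc3)C2)cc1` remains to be measured in this assay. For the measured compounds named here, it differs from compound 3 by phenyl in place of ethynyl on a saturated chain carbon bound to an amine nitrogen in a ring, the same change, at the same place word for word, as the one from compound 1 to compound 2. The step expected from compound 3 to compound 4 is a step that the limit leaves unreadable from compound 3 to compound 4, set beside the earlier step that the two limits leave unreadable from compound 1 to compound 2; the expectation rests on (the limit of > 100000 nM in this assay, at which 3 of the 3 values shown sit), which gives no sign that this change moves a compound off the limit. Compound 4 is therefore estimated at 150000 nM, with a range from 30000 nM to 1000000 nM, and most likely it will again be reported only as a limit in this assay.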

Compound 4, half-maximal inhibitory concentration: > 100000 nM
Compound 4: only a limit was reported (the forecaster's own chance of this, stated with the estimate: 85%); the middle value does not contradict the limit.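

In this assay compound 4 gives > 100000 nM, which is a limit and not a number. Among the compounds shown here, compound 3 also stands at a limit, so the step between compound 3 and compound 4 cannot be read and no new step arises. The compounds shown leave open what structure, if any, gives a measurable value in this assay: the limit of > 100000 nM in this assay, at which 4 of the 4 values shown sit.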